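Fluoro to trifluoromethoxy on the shared core

A few compounds are considered here, and "the series" means these few. Any claim that something is new, unique, unknown or untested is made for them only; others in the source may bear on it.

Measured:
- compound 1 `CC(C)(C)c1ccccc1-c1ccc2[nH]ncc2c1` — 3400 nM
- compound 2 `Fc1cc2[nH]ncc2cc1-c1ccccc1C(F)(F)F` — 48 nM

In an assay on CHO-TREX cells for antagonist activity at transient receptor potential cation channel subfamily A member 1 (Homo sapiens), read by FLIPR and calcium flux, with a stated time of 10 min (on this read-out higher numbers stand for weaker inhibition and lower numbers for stronger inhibition), compound 2 stands lowest of the two numbers; compound 1 gives 3400 nM, a difference beyond the scatter. Compound 3 `FC(F)(F)Oc1cc2[nH]ncc2cc1-c1ccccc1C(F)(F)F` is not yet measured. It differs from compound 2 by trifluoromethoxy in place of fluoro on an aromatic carbon. Within the data shown here, no measured pair shows this change, so the direction is uncertain; the step of a 1.9-fold higher number from compound 2 to compound 3 (0.27 log units; within the scatter) is expected to stay near or only modestly beyond the scatter. Compound 3 is estimated at 90 nM, with a range from 30 nM to 300 nM.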

Compound 3, half-maximal inhibitory concentration: 36 nM
Beside the measured number, compound 3's estimate is 2.5-fold (0.40 log units) above it, within the range that was stated.
By their numbers in this assay, from the lowest: compounds 3 and 2 (each within the scatter of the next); then compound 1.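

On the aromatic carbon ortho to a large group, trifluoromethoxy in place of fluoro gives a 1.3-fold lower number from compound 2 to compound 3 (0.12 log units; within the scatter) in this assay. This position therefore accepts a group of five heavy atoms in place of one, with the two compounds staying within the scatter of each other. Nothing at hand explains this result.

On these data alone, whether an amine, a carboxylic acid or a longer alkoxy chain on this carbon would keep the number in this range stays open. So does the effect of plain hydrogen there.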